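The source may hold more compounds than are shown below. What is called first, only, known or untested is meant among the compounds shown, and "the series" means these compounds.

Within the data shown here, compound 2 `Cn1ccc2c(Oc3ccc(NC(=O)c4cc5cccnc5n(-c5ccc(Br)cc5)c4=O)cc3F)ccnc21` stands at the lower of the two numbers known so far: in a functional assay on A549 cells (Homo sapiens) for antiproliferative activity, read by MTT assay, with a stated time of 72 h (a higher number here means a weaker inhibitor, a lower number a stronger inhibitor), compound 2 gives 390 nM. Compound 1 `Cn1ccc2c(Oc3ccc(NC(=O)c4cc5cccnc5n(-c5ccc(Br)cc5F)c4=O)cc3)ccnc21` gives 1630 nM in this assay; since the two differ in more than one place, their numbers can only be set side by side. Compound 3 `Cn1ccc2c(Oc3ccc(NC(=O)c4cc5cccnc5n(-c5ccc(Br)cc5F)c4=O)cc3F)ccnc21` differs from compound 2 by fluoro in place of hydrogen on an aromatic carbon. Among the measured compounds shown here, no measured step of this single kind exists here, so a change within the scatter, or at most a mild weakening, is expected. Compound 3 is therefore estimated at 550 nM, with a range from 150 nM to 1800 nM. The expected step is a 1.4-fold higher number from compound 2 to compound 3 (0.15 log units; within the scatter).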

Compound 3, half-maximal inhibitory concentration: 2690 nM
For compound 3 the middle estimate is 4.9-fold (0.69 log units) below the measured one; the measured number lies above the stated range.
By their numbers in this assay, from the lowest: compound 2; then compounds 1 and 3 (each within the scatter of the next).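

Placing fluoro on the 4-bromophenyl group, making it 4-bromo-2-fluorophenyl, is not a neutral change: this assay shows a 6.9-fold higher number from compound 2 to compound 3 (0.84 log units; beyond the scatter) and thus a real loss of activity. The other single fluoro change, at a different aromatic carbon, gives a 1.7-fold higher number from compound 1 to compound 3 (0.22 log units; within the scatter) and cannot be told from no change. Among these three compounds, then, the cost follows the fluoro on the bromophenyl group.

On these data alone, whether chloro or methoxy at this place would cost as much remains open. The reason for the loss also stays open, as no measurement here bears on it.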